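The source may report more compounds than this note shows. Statements on the series, on what has been measured and on what is new or still open speak of the compounds shown alone.

Measured in a functional assay on T47D cells (Homo sapiens) for inhibition, read by sulforhodamine B assay, with a stated time of 48 h; on this read-out lower numbers stand for stronger inhibition of growth and higher numbers for weaker inhibition of growth:
compound 1 `COC(=O)[C@@]1(C)CC[C@@H]2C3=C1CC[C@@H](C)[C@]3(C)C[C@@H]1c3cc(C)ccc3N[C@H]21` gives 23000 nM;
compound 2 `COC(=O)[C@@]1(C)CC[C@@H]2C3=C1CC[C@@H](C)[C@]3(C)C[C@@H]1c3cc(Cl)ccc3N[C@H]21` gives 28000 nM;
compound 3 `COC(=O)[C@@]1(C)CC[C@@H]2C3=C1CC[C@@H](C)[C@]3(C)C[C@@H]1c3cc(F)ccc3N[C@H]21` gives 27000 nM.

Compound 3 stands among these three numbers with no gap beyond the scatter to either of the others: the step of a 1.0-fold lower number from compound 2 to compound 3 (0.02 log units; within the scatter) is the smallest, and the step of a 1.2-fold higher number from compound 1 to compound 3 (0.07 log units; within the scatter) is only a little larger, so nothing separates compound 3 from compound 1 or compound 2. Compound 4 `COC(=O)[C@@]1(C)CC[C@@H]2C3=C1CC[C@@H](C)[C@]3(C)C[C@@H]1c3cc(OC)ccc3N[C@H]21` has not yet been measured in this assay. It differs from compound 3 in one place: methoxy in place of fluoro on an aromatic carbon. Going by the values given here, the steps that bear on this change are the three already seen at the same aromatic carbon: a 1.2-fold higher number from compound 1 to compound 2 (0.09 log units; within the scatter), a 1.2-fold higher number from compound 1 to compound 3 (0.07 log units; within the scatter) and a 1.0-fold lower number from compound 2 to compound 3 (0.02 log units; within the scatter). Each of these exchanges of one substituent for another at that carbon left the number where it was. On that ground the expected step of no change at the digits printed from compound 3 to compound 4 (within the scatter) in this assay is none beyond the scatter, in either direction. Compound 4 is accordingly estimated at 27000 nM, with a range from 12000 nM to 60000 nM. This estimate rests on compound 3, which gives 27000 nM, and on the three measured steps above.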

Compound 4, concentration for 50% growth inhibition: 19000 nM
For compound 4 the middle estimate is 1.4-fold (0.15 log units) above the measured one; measured number inside the range.
By their numbers in this assay, from the lowest: compounds 4, 1, 3 and 2 (each within the scatter of the next).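

In this assay, methoxy at this aromatic carbon carries a hydrogen-bond acceptor and two heavy atoms where fluoro has no acceptor and one heavy atom, yet it stays within the scatter of all three earlier substituents: fluoro (a 1.4-fold lower number from compound 3 to compound 4 (0.15 log units; within the scatter)), chloro (a 1.5-fold lower number from compound 2 to compound 4 (0.17 log units; within the scatter)) and methyl (a 1.2-fold lower number from compound 1 to compound 4 (0.08 log units; within the scatter)). The earlier compounds had shown this only for methyl, chloro and fluoro, so the flat picture at this place, meta to a fused ring and para to a fused ring, now also covers a substituent attached through oxygen, with none of the four separated from another by more than the scatter. No measurement at hand accounts for this lack of separation.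

The compounds shown leave open whether any group at this carbon can move the number beyond the scatter, for instance an amine, a carboxylic acid or a longer chain such as butoxy, or whether plain hydrogen there would read the same. They also leave open whether this insensitivity would persist if the methyl ester elsewhere on the shared core were replaced by a carboxylic acid or an amide.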